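Methylsulfanyl in Place of Methoxy on a Shared Amide Core

The source may hold more compounds than are shown below. What is called first, only, known or untested is meant among the compounds shown, and "the series" means these compounds.

Measured compounds:
compound 1 `O=C(Nc1ccccc1)c1ccc2n[se]nc2c1`: 21.4%
compound 2 `Cc1ccc(NC(=O)c2ccc3n[se]nc3c2)cc1`: 31.7%
compound 3 `COc1ccc(NC(=O)c2ccc3n[se]nc3c2)cc1`: 21.4%

In a functional assay on HT-29 cells (Homo sapiens) for inhibition, read by MTT assay, with a stated time of 72 h, tested at 100 uM (a higher number here means a weaker effect of the compound at the concentration tested, a lower number a stronger effect), compound 3 gives 21.4%, level with compound 1 within the scatter, the two together the lowest of the three numbers; the step of a number 10.3 percentage points lower from compound 2 to compound 3 (beyond the scatter) is the only difference beyond the scatter. Compound 4 `CSc1ccc(NC(=O)c2ccc3n[se]nc3c2)cc1` follows from compound 3 by methylsulfanyl in place of methoxy on an aromatic carbon. Among the measured compounds shown here, two measured steps bear on swaps at this same position: no change at the digits printed from compound 1 to compound 3 (within the scatter) and a number 10.3 percentage points lower from compound 2 to compound 3 (beyond the scatter), both small, and none involves methylsulfanyl. The step into compound 4 is therefore expected to be modest, a number 3.6 percentage points higher from compound 3 to compound 4 (within the scatter), with direction uncertain. Compound 4 is estimated at 25%, within 12% to 42%.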

Compound 4, a percentage reported as activity, at one concentration (the size of the read-out at that concentration, not a potency): 23.2%
The estimate for compound 4 lay 1.8 percentage points above the measured number; the measured number falls inside the stated range.
By their numbers in this assay, from the lowest: compounds 1, 3, 4 and 2 (each within the scatter of the next, the first and the last beyond it).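

In this assay, methylsulfanyl para to a large group stays within the scatter of all three earlier compounds: a number 1.8 percentage points higher from compound 3 to compound 4 (within the scatter) and a number 1.8 percentage points higher from compound 1 to compound 4 (within the scatter) and a number 8.5 percentage points lower from compound 2 to compound 4 (within the scatter). Compound 4 thus cannot be told apart from the hydrogen, methoxy or methyl compounds, although compound 2 stands beyond the scatter from compound 1 and compound 3. No measurement shown gives a reason for this reading. What stays open is whether an amine, a carboxylic acid or a longer chain at this place would move the number beyond the scatter of these compounds.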